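A few compounds are considered here, and "the series" means these few. Any claim that something is new, unique, unknown or untested is made for them only; others in the source may bear on it.

The compounds measured in a functional assay on CHO-K1 cells for antagonist activity at transient receptor potential cation channel subfamily V member 1 (Homo sapiens), read by FLIPR (a lower number here means a stronger inhibitor, a higher number a weaker inhibitor), are:

compound 1, `CC(C(=O)NCc1ccc(C(F)(F)F)nc1Nc1ccc(F)cc1)c1ccc(NS(C)(=O)=O)c(F)c1`: 39.2 nM
compound 2, `Cc1ccc(Nc2nc(C(F)(F)F)ccc2CNC(=O)C(C)c2ccc(NS(C)(=O)=O)c(F)c2)cc1C`: 39.3 nM
compound 3, `CC(C(=O)NCc1ccc(C(F)(F)F)nc1N(C)C)c1ccc(NS(C)(=O)=O)c(F)c1`: 19.1 nM

Compound 3 gives the lowest of the three numbers: a 2.1-fold lower number from compound 1 to compound 3 (0.31 log units; beyond the scatter) and a 2.1-fold lower number from compound 2 to compound 3 (0.31 log units; beyond the scatter), both modest steps beyond the scatter, while a 1.0-fold higher number from compound 1 to compound 2 (0.00 log units; within the scatter) lies within it. Compound 4, `CC(C(=O)NCc1ccc(C(F)(F)F)nc1N1CCCC1)c1ccc(NS(C)(=O)=O)c(F)c1`, has not been measured. It differs from compound 3 in one place: pyrrolidin-1-yl in place of dimethylamino on an aromatic carbon. Going by the values given here, no measured pair changes dimethylamino to a ring amine; the two steps into compound 3 only show that swapping an arylamino for dimethylamino at this carbon lowered the number modestly. Compound 4 is therefore expected to give a number close to that of compound 3, with a 1.2-fold higher number from compound 3 to compound 4 (0.06 log units; within the scatter) expected to stay within the scatter. The estimate for compound 4 in this assay is 22 nM, between 9 nM and 55 nM.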

Compound 4, inhibition constant: 0.6 nM
Estimate against measurement, compound 4: 37-fold (1.56 log units) above; the whole stated range lies above it.
By their numbers in this assay, from the lowest: compound 4; then compound 3; then compounds 1 and 2 (each within the scatter of the next).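

At this aromatic carbon next to the ring nitrogen, in this assay, pyrrolidin-1-yl in place of dimethylamino gives a 32-fold lower number from compound 3 to compound 4 (1.50 log units; beyond the scatter), so the position responds sharply to the form of the amine and not only to the loss of an arylamino group. The same group also stands far from both arylamino compounds, with a 65-fold lower number from compound 1 to compound 4 (1.82 log units; beyond the scatter) and a 66-fold lower number from compound 2 to compound 4 (1.82 log units; beyond the scatter), steps much larger than either step into compound 3. Nothing measured here accounts for this jump. Going by these compounds, it remains open whether the effect belongs to the five-membered ring itself. Azetidine, piperidine, morpholine or an open diethylamino group at this carbon would separate ring size from ring closure.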